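The source may report more compounds than this note shows. Statements on the series, on what has been measured and on what is new or still open speak of the compounds shown alone.

Compound 1 `COC1=C(C)C(=O)/C(=C(O)/C=C/c2cccc(OC)c2)C(=O)C1(C)C` is the starting point of the step followed here. In a functional assay on HCT-8 cells (Homo sapiens) for cytotoxicity (a lower number here means that less compound is needed, a higher number that more compound is needed for the effect), compound 1 gives 2.9 ug/mL, the lowest number among the three measured compounds. Compound 3 `COC1=C(C)C(=O)/C(=C(O)/C=C/c2ccccc2C)C(=O)C1(C)C` gives 4 ug/mL in this assay, and the step of a 1.4-fold higher number from compound 1 to compound 3 (0.14 log units; within the scatter) stays within the scatter. Compound 2 `COC1=C(C)C(=O)/C(=C(O)/C=C/c2ccc(O)cc2)C(=O)C1(C)C` gives 14.8 ug/mL; the step of a 5.1-fold higher number from compound 1 to compound 2 (0.71 log units; beyond the scatter) lies beyond the scatter, and so does the step of a 3.7-fold lower number from compound 2 to compound 3 (0.57 log units; beyond the scatter).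

Compound 4 `COC1=C(C)C(=O)/C(=C(O)/C=C/c2nccs2)C(=O)C1(C)C` has not yet been measured. It differs from compound 1 in one place: 1,3-thiazol-2-yl in place of 3-methoxyphenyl on a double-bonded chain carbon bound to a double-bonded chain carbon. Among the measured compounds shown here, none of the measured steps exchanges the six-membered aromatic ring for a five-membered aromatic ring with hetero atoms; the measured steps only vary the group carried on that ring. They show that putting 2-methylphenyl in place of 3-methoxyphenyl leaves the number within the scatter, whereas putting 4-hydroxyphenyl in its place raises it modestly. The change to 1,3-thiazol-2-yl is of a different kind from either, so the author allows a wider spread and expects, if anything, a modest rise in the number. Compound 4 is therefore estimated at 5 ug/mL, with a range from 2 ug/mL to 12 ug/mL, which corresponds to an expected step of a 1.7-fold higher number from compound 1 to compound 4 (0.24 log units; within the scatter).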

Compound 4, concentration for half-maximal effect: 5.1 ug/mL
Compound 4: the middle estimate sits 1.0-fold (0.01 log units) below what was measured, within the range that was stated.
By their numbers in this assay, from the lowest: compounds 1, 3 and 4 (each within the scatter of the next); then compound 2.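

In this assay, the step of a 1.8-fold higher number from compound 1 to compound 4 (0.25 log units; within the scatter) and the step of a 1.3-fold higher number from compound 3 to compound 4 (0.11 log units; within the scatter) show that, on a double-bonded chain carbon bound to a double-bonded chain carbon, a five-membered aromatic ring with 2 hetero atoms can stand in place of a six-membered aromatic ring of carbon only without moving the number beyond the scatter. Compounds 1, 3 and 4 thus group together, and the only one of the four set apart from the others is the one with 4-hydroxyphenyl, as the step of a 2.9-fold lower number from compound 2 to compound 4 (0.46 log units; beyond the scatter) shows, so the exchange of ring type in this series matters less here than the hydroxyl-bearing phenyl does. Nothing in hand accounts for these numbers or links them to any feature of the 1,3-thiazol-2-yl group.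

The compounds shown leave open whether the nitrogen or the sulfur of the 1,3-thiazol-2-yl ring is needed for this result, which a furan-2-yl or a pyridin-2-yl group at the same place would help to test. They also leave open how a 1,3-thiazol-2-yl ring carrying a hydroxyl, an amine or a carboxylic acid would read in this assay.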